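The source may report more compounds than this note shows. Statements on the series, on what has been measured and on what is new or still open speak of the compounds shown alone.

Compound 1 `CC1(C)[C@H]2CC[C@]1(C)[C@H](OC(=O)CCCN1CCCCC1)C2` gives 74800 nM in an ADME assay on HEK-293T cells (Homo sapiens) for cytotoxicity, read by MTT assay, with a stated time of 48 h; a lower number here means that less compound is tolerated, a higher number that more compound is tolerated. Compound 2 `CC1CCN(CCCCC(=O)O[C@@H]2C[C@@H]3CC[C@@]2(C)C3(C)C)CC1` gives 73000 nM. Compound 3 `CN1CCN(CCCC(=O)O[C@@H]2C[C@@H]3CC[C@@]2(C)C3(C)C)CC1` gives 99200 nM.

Compound 3 holds the highest of the three numbers, yet the steps leading to it, a 1.3-fold higher number from compound 1 to compound 3 (0.12 log units; within the scatter) and a 1.4-fold higher number from compound 2 to compound 3 (0.13 log units; within the scatter), both fall within the scatter, so the three compounds cannot be ranked. Compound 4 `CC1(C)[C@H]2CC[C@]1(C)[C@H](OC(=O)CCCN1CCCCCC1)C2` differs from compound 3 by azepan-1-yl in place of 4-methylpiperazin-1-yl on a saturated chain carbon, three bonds along the chain from a carbonyl carbon. Every measured step exchanges the amine ring at this same place, and each stayed within the scatter: a 1.0-fold lower number from compound 1 to compound 2 (0.01 log units; within the scatter), a 1.3-fold higher number from compound 1 to compound 3 (0.12 log units; within the scatter) and a 1.4-fold higher number from compound 2 to compound 3 (0.13 log units; within the scatter). No step beyond the scatter is therefore expected in this assay, in either direction. Compound 4 is estimated at 80000 nM, with a range from 40000 nM to 160000 nM. The expected step is a 1.2-fold lower number from compound 3 to compound 4 (0.09 log units; within the scatter).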

Compound 4, half-maximal cytotoxic concentration: 62200 nM
Estimate against measurement, compound 4: 1.3-fold (0.11 log units) above; measured number inside the range.
By their numbers in this assay, from the lowest: compounds 4, 2, 1 and 3 (each within the scatter of the next).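

In this assay the seven-membered azepan-1-yl ring stays within the scatter of all three six-membered-ring compounds, with a 1.6-fold lower number from compound 3 to compound 4 (0.20 log units; within the scatter) and a 1.2-fold lower number from compound 2 to compound 4 (0.07 log units; within the scatter) and a 1.2-fold lower number from compound 1 to compound 4 (0.08 log units; within the scatter) as its steps. A larger ring, with one ring nitrogen where compound 3 has two, thus brings no step beyond the scatter at this place. Nothing at hand gives a reason for this.

Going by these compounds, whether a morpholine ring or a carboxylic acid at this place would also stay within the scatter remains open.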